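Working notes: 2-cyanophenyl to 4-chlorophenyl step

A few compounds are considered here, and "the series" means these few. Any claim that something is new, unique, unknown or untested is made for them only; others in the source may bear on it.

Values in a functional assay on B16 cells (Mus musculus) for antiproliferative activity, read by MTT assay, with a stated time of 24 h; a lower number here means a stronger inhibitor, a higher number a weaker inhibitor:
- compound 1 `COc1cc(OC)c(-c2coc3cc(OCc4ccccc4)ccc3c2=O)cc1OC`: 2330 nM
- compound 2 `COc1cc(OC)c(-c2coc3cc(OCc4ccccc4C(F)(F)F)ccc3c2=O)cc1OC`: 8550 nM
- compound 3 `COc1cc(OC)c(-c2coc3cc(OCc4ccccc4C#N)ccc3c2=O)cc1OC`: 2140 nM

Compound 3 sits at the low end of these numbers, together with one other: a 1.1-fold lower number from compound 1 to compound 3 (0.04 log units; within the scatter). The remaining one lies clear of it: a 4.0-fold lower number from compound 2 to compound 3 (0.60 log units; beyond the scatter).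

The next compound is compound 4 `COc1cc(OC)c(-c2coc3cc(OCc4ccc(Cl)cc4)ccc3c2=O)cc1OC`, still unmeasured. The change is 4-chlorophenyl in place of 2-cyanophenyl on a saturated chain carbon bound to an oxygen on an aromatic ring.

For the measured compounds named here, no measured compound carries 4-chlorophenyl, so the evidence is indirect. Adding cyano left the number unchanged within the scatter, as a 1.1-fold lower number from compound 1 to compound 3 (0.04 log units; within the scatter) shows, so losing it should cost little. Trifluoromethyl shows that a substituent can matter, with a 3.7-fold higher number from compound 1 to compound 2 (0.56 log units; beyond the scatter) as the only upward step of this kind.

A small move is therefore expected in this assay, with some risk towards higher numbers. The expected step is a 1.4-fold higher number from compound 3 to compound 4 (0.15 log units; within the scatter), a slightly higher number. The estimate for compound 4 is 3000 nM, with an expected range of 1200 nM to 7500 nM.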

Compound 4, half-maximal inhibitory concentration: 2400 nM
The estimate for compound 4 lay 1.3-fold (0.10 log units) above the measured number; the range from low to high includes it.
By their numbers in this assay, from the lowest: compounds 3, 1 and 4 (each within the scatter of the next); then compound 2.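

In this assay, adding chloro gives a second substituent, after cyano, that leaves the number level with the unsubstituted compound (a 1.0-fold higher number from compound 1 to compound 4 (0.01 log units; within the scatter)). The exchange of 2-cyanophenyl for 4-chlorophenyl on a saturated chain carbon bound to an oxygen on an aromatic ring likewise makes no readable difference (a 1.1-fold higher number from compound 3 to compound 4 (0.05 log units; within the scatter)). Against this stands 2-(trifluoromethyl)phenyl, the only one of the four groups that lies apart (a 3.6-fold lower number from compound 2 to compound 4 (0.55 log units; beyond the scatter)), so substitution on this ring carries no general penalty among these compounds.

As far as these compounds go, whether any group here gives a number clearly lower than compound 1 remains open, as does the outcome with an amine or a carboxylic acid on this ring. Nothing available explains why compound 2 alone stands apart.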